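Aryl swap on the shared core: chlorophenyl to furan

The source may report more compounds than this note shows. Statements on the series, on what has been measured and on what is new or still open speak of the compounds shown alone.

Going by the values given here, compound 2 `Nc1ncnn2c([C@@H]3O[C@H](CO)[C@@H](O)[C@H]3O)cc(-c3ccc(Cl)cc3)c12` holds the only numeric value in a functional assay on LN-229 cells (Homo sapiens) for antiproliferative activity, with a stated time of 72 h; a lower number here means a stronger inhibitor, a higher number a weaker inhibitor: compound 2 gives 32600 nM. Compound 1 `Nc1ncnn2c([C@@H]3O[C@H](CO)[C@@H](O)[C@H]3O)cc(C#Cc3cccs3)c12` sits at a limit of this assay, > 100000 nM. Among the compounds with values here, the single measured step is an at least 3.0-fold lower number from compound 1 to compound 2 (0.48 log units; beyond the scatter), and its size is set by the limit of > 100000 nM in this assay, at which 1 of the 2 values shown sits. Compound 3 `Nc1ncnn2c([C@@H]3O[C@H](CO)[C@@H](O)[C@H]3O)cc(-c3ccoc3)c12` differs from compound 2 by furan-3-yl in place of 4-chlorophenyl on an aromatic carbon. Within the data shown here, only that one step bears on the change, and it gives no clear direction for a smaller five-membered ring without the ethynyl link; a small step of a 1.7-fold higher number from compound 2 to compound 3 (0.23 log units; within the scatter) toward a weaker value is expected. Compound 3 is estimated at 55000 nM, between 18000 nM and 170000 nM.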

Compound 3, half-maximal inhibitory concentration: 1000 nM
Estimate against measurement, compound 3: 55-fold (1.74 log units) above; the measured number lies below the stated range.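

Replacing 4-chlorophenyl with furan-3-yl on this aromatic carbon gives a 33-fold lower number from compound 2 to compound 3 (1.51 log units; beyond the scatter) in this assay, so this position tolerates large shifts in activity with a single ring change, which the earlier step could not show in full. Against the 2-(thiophen-2-yl)ethynyl group, furan-3-yl gives an at least 100-fold lower number from compound 1 to compound 3 (2.00 log units; beyond the scatter), and the size of that step is bounded by a limit and not fixed by a number: the limit of > 100000 nM in this assay, at which 1 of the 3 values shown sits.

The compounds shown do not separate the effect of ring size from that of the ring oxygen. Phenyl, thiophen-3-yl and furan-2-yl on this carbon would bear on that question.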